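This account rests on a few compounds, and the source may have more. Where it says the series, first, only, none or still open, it means among the compounds named here.

Compound 1 `O=C1C=C[C@@H](OCc2ccccc2)[C@@H]([C@@H](COC(=O)/C=C/c2ccccc2)OCc2ccccc2)O1` is the reference point of the series. In a functional assay on Raji cells (Homo sapiens) for antiproliferative activity, read by MTT assay, with a stated time of 6 days (on this read-out lower numbers stand for stronger inhibition and higher numbers for weaker inhibition), compound 1 gives 1330 nM. Among the measured compounds shown here, the only other measured member, compound 2 `COc1cccc(C(=O)OC[C@@H](OC(=O)c2cccc(OC)c2)[C@H]2OC(=O)C=C[C@H]2OC(=O)c2cccc(OC)c2)c1`, is read in the same way; in this assay compound 2 gives 2690 nM. Of the two numbers, compound 1 has the lower one, and the gap to compound 2 lies beyond the usual scatter of repeated measurements, so compound 1 is the stronger inhibitor of the pair.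

Compound 3 `CC(=O)OC[C@@H](OCc1ccccc1)[C@H]1OC(=O)C=C[C@H]1OCc1ccccc1` has not yet been measured in this assay. It differs from compound 1 in one place: methyl in place of 2-phenylethenyl on a carbonyl carbon. For the measured compounds named here, no measured pair shows this change, so nothing measured fixes the size of the step; what follows is expectation only. Replacing the 2-phenylethenyl by methyl is expected to move the number upward, that is toward weaker inhibition, by a step of a 2.4-fold higher number from compound 1 to compound 3 (0.38 log units; beyond the scatter), modest but likely beyond the scatter. Compound 3 is therefore estimated at 3200 nM in this assay, with a range from 1100 nM to 9500 nM.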

Compound 3, half-maximal inhibitory concentration: 1820 nM
Estimate against measurement, compound 3: 1.8-fold (0.25 log units) above; the range from low to high includes it.
By their numbers in this assay, from the lowest: compounds 1, 3 and 2 (each within the scatter of the next, the first and the last beyond it).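

In this assay, among the compounds shown here, replacing 2-phenylethenyl by methyl on a carbonyl carbon gives a 1.4-fold higher number from compound 1 to compound 3 (0.14 log units; within the scatter), the first one-place comparison, as compound 1 and compound 2 differ in more than one place. Within this pair, the (2-phenylethenyl)carbonyl group, with its six-membered aromatic ring and its double bond outside aromatic rings, can give way to acetyl without a change that stands out from the usual scatter, so that ring and double bond are not required at this position for a reading in this range on the core of compound 1. No measured information on the compounds bears on why this exchange leaves the reading within the scatter.

Open, on these data alone, is whether a longer alkyl chain, an amine or a carboxylic acid on this carbonyl carbon would leave the reading within the scatter as well, and whether a plain hydroxymethyl could stand in place of acetoxymethyl. Also open, as far as these compounds go, is whether this result holds with groups other than the benzyl ethers of compound 1 and compound 3 elsewhere on the core.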